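A few compounds are considered here, and "the series" means these few. Any claim that something is new, unique, unknown or untested is made for them only; others in the source may bear on it.

Series notes, step from compound 3 to compound 4. Compound 1 `NC1=NC2(CCOCC2)N(OCCCOc2cccc(Cl)c2)C(N)=N1`, compound 2 `NC1=NC2(CCOCC2)N(OCCCOc2ccccc2Cl)C(N)=N1` and compound 3 `NC1=NC2(CCOCC2)N(OCCCOc2ccc(Cl)cc2Cl)C(N)=N1` have been tested in an assay on isolated protein for inhibition of Dihydrofolate reductase (Homo sapiens), read by spectrophotometry, using NADPH, with stated times of 5 s and 6 min, tested at 5 uM; a lower number here means a weaker effect, a higher number a stronger effect of the compound at the concentration tested. Compound 1 gives 83.2%. Compound 2 gives 83.3%. For compound 3 the assay reports only a limit, > 90%, not a number (the limit of > 90% in this assay, at which 1 of the 3 values shown sits). The measured steps were a number 0.1 percentage points higher from compound 1 to compound 2 (within the scatter), a number at least 6.8 percentage points higher from compound 1 to compound 3 (that floor lies within the scatter) and a number at least 6.7 percentage points higher from compound 2 to compound 3 (that floor lies within the scatter). Compound 4 `COc1ccc(OCCCON2C(N)=NC(N)=NC23CCOCC3)cc1` is not yet measured; it differs from compound 3 by 4-methoxyphenyl in place of 2,4-dichlorophenyl on an oxygen on a saturated carbon. The two steps into compound 3 bear on this change in the opposite direction, and each gives only a floor that lies within the scatter, so a fall no larger than the scatter is expected. Compound 4 is expected to give 80%, between 62% and 92%, a step of a number at least 10 percentage points lower from compound 3 to compound 4 (that floor lies within the scatter).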

Compound 4, a percentage reported as inhibition, at one concentration (the size of the read-out at that concentration, not a potency): > 90%
Compound 4: no number, only a limit; the forecaster's own chance of this, stated with the estimate: 15%; at least 10 percentage points between middle value and limit.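

In this assay compound 4 gives > 90%, a limit and not a number. A 4-methoxyphenyl on this oxygen therefore reaches the limit without any chloro on the ring, with steps of a number at least 6.7 percentage points higher from compound 2 to compound 4 (that floor lies within the scatter) and a number at least 6.8 percentage points higher from compound 1 to compound 4 (that floor lies within the scatter). The step between compound 3 and compound 4 cannot be read, and this end of the scale is now crowded: the limit of > 90% in this assay, at which 2 of the 4 values shown sit.

Going by these compounds, whether 4-methoxyphenyl and 2,4-dichlorophenyl differ at all stays open. So does how an amine or a carboxylic acid on this ring, or a longer chain in place of the present one, would read in this assay.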